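Oxazole-carboxamide piperazines: aryl swap on the ring amine

A few compounds are considered here, and "the series" means these few. Any claim that something is new, unique, unknown or untested is made for them only; others in the source may bear on it.

Measured so far:
compound 1, `Cc1nc(-c2ccccc2)c(C(=O)N2CCN(c3cccc(C(N)=O)c3)CC2)o1`, 71 nM
compound 2, `Cc1nc(-c2ccc(F)cc2)c(C(=O)N2CCN(c3cc(Cl)cc(Cl)c3)CC2)o1`, 52.1 nM

Both values come from a functional assay on HL-60 cells (Homo sapiens) for inhibition, read by MTT assay, with a stated time of 72 h; on this read-out higher numbers stand for weaker inhibition and lower numbers for stronger inhibition. Within the data shown here, compound 1 and compound 2 give numbers that lie within the scatter of each other, so the two cannot be ordered on this read-out; no stepwise pair with a single structural change is among them.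

Compound 3, `Cc1nc(-c2ccccc2)c(C(=O)N2CCN(c3ccccc3C(F)(F)F)CC2)o1`, is the next member to be measured in this assay. It differs from compound 1 in one place: 2-(trifluoromethyl)phenyl in place of 3-carbamoylphenyl on an amine nitrogen in a ring. Among the measured compounds shown here, the group that leaves carries one hydrogen-bond donor and one acceptor; the group that enters carries none, and the two measured compounds give no step on which such a change could be read.

For the measured compounds named here, with no comparable step in hand, a modest change in either direction is expected, most likely none beyond the scatter. The estimated step of a 1.4-fold higher number from compound 1 to compound 3 (0.15 log units; within the scatter) reflects this. Compound 3 is expected to give about 100 nM in this assay, within 25 nM to 400 nM.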

Compound 3, half-maximal inhibitory concentration: 120 nM
Compound 3: the middle estimate sits 1.2-fold (0.08 log units) below what was measured, within the range that was stated.
By their numbers in this assay, from the lowest: compounds 2, 1 and 3 (each within the scatter of the next, the first and the last beyond it).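

In this assay, 2-(trifluoromethyl)phenyl in place of 3-carbamoylphenyl on the amine nitrogen in the ring gives a 1.7-fold higher number from compound 1 to compound 3 (0.23 log units; within the scatter). Among these compounds, this is the first single-place step. It shows that, at this position, a group carrying a hydrogen-bond donor and acceptor can be exchanged for one carrying neither without a step beyond the scatter.

The swap alters both the substituent and its place on the phenyl ring, so neither can be read alone. From the compounds shown here alone, how a phenyl ring with an aminomethyl group or a carboxylic acid would read at this position stays open, as does a plain phenyl ring on the same nitrogen. No measurement at hand bears on the reason for this result.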